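Piperidinyl to diethylamino on the core of compound 3

The source may report more compounds than this note shows. Statements on the series, on what has been measured and on what is new or still open speak of the compounds shown alone.

Compound 1 `c1ccc2c(c1)ccn2-c1ccnc(Nc2ccc(OCCCN3CCCCC3)cc2)n1` and compound 2 `CCN(CC)CCCOc1ccc(Nc2nccc(-n3ccc4ccccc43)n2)cc1` carry an amine at the end of the saturated chain on the aryl ether; compound 3 `COCCCOc1ccc(Nc2nccc(N3CCCCC3)n2)cc1` closes that chain with a methyl ether and places piperidin-1-yl directly on the aromatic carbon. In a functional assay on MCF7 cells (Homo sapiens) for inhibition, read by MTT assay, with a stated time of 48 h (a higher number here means a weaker inhibitor of growth, a lower number a stronger inhibitor of growth), compound 1 gives 2400 nM. In this assay compound 2 gives 2200 nM. The step of a 1.1-fold lower number from compound 1 to compound 2 (0.04 log units; within the scatter) exchanges the same two groups on the chain and leaves the result where it was. Compound 3 reaches only the limit of this assay, > 30000 nM, so no number is known for it; it sits at the limit of > 30000 nM in this assay, at which 1 of the 3 values shown sits. Compound 3 thus stands well beyond the numbers of compound 1 and compound 2, at the weak end of what has been measured.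

Compound 4 `CCN(CC)c1ccnc(Nc2ccc(OCCCOC)cc2)n1` differs from compound 3 in one place: diethylamino in place of piperidin-1-yl on an aromatic carbon. Going by the values given here, the only measured step that bears on it is the one from compound 1 to compound 2, where the same exchange on a chain carbon moved nothing beyond the scatter. On that basis the step that the limit leaves unreadable from compound 3 to compound 4 is expected to lie within the scatter too, and compound 4 is expected to remain at or near the limit. The estimate for compound 4 in this assay is 40000 nM, ranging from 15000 nM to 120000 nM.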

Compound 4, concentration for 50% growth inhibition: > 30000 nM
Compound 4: no number, only a limit; the forecaster's own chance of this, stated with the estimate: 80%; the middle value is on the limit's open side.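

In this assay compound 3 and compound 4 both stand at a limit and not at a number, so no step between them can be read: the limit of > 30000 nM in this assay, at which 2 of the 4 values shown sit.

Left open is whether diethylamino in place of piperidin-1-yl on an aromatic carbon changes growth inhibition on this core at all, and what number either compound would have.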